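Methoxy in Place of Methyl on the Shared Core

The source may report more compounds than this note shows. Statements on the series, on what has been measured and on what is new or still open speak of the compounds shown alone.

Compound 1 `Cc1cccc(Cn2cc(COc3ccc4c(=O)ccoc4c3)nn2)c1`: in a functional assay on SGC-7901 cells (Homo sapiens) for cytotoxicity, read by MTT assay, with a stated time of 48 h (on this read-out higher numbers stand for weaker inhibition and lower numbers for stronger inhibition), compound 1 gives > 100000 nM, a limit of the assay.
Compound 2 `Cc1ccc(Cn2cc(COc3ccc4c(=O)ccoc4c3)nn2)cc1`: in this assay compound 2 gives > 100000 nM, a limit of the assay.
Compound 3 `O=c1ccoc2cc(OCc3cn(Cc4ccc(F)cc4)nn3)ccc12`: in this assay compound 3 gives > 100000 nM, a limit of the assay.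

Compound 2 therefore stands only at a limit, and the three values shown are all limits, so that the limit of > 100000 nM in this assay, at which 3 of the 3 values shown sit, is the whole of what the measured series says. None of the steps among them can be read: a step that the two limits leave unreadable from compound 1 to compound 2; a step that the two limits leave unreadable from compound 1 to compound 3; a step that the two limits leave unreadable from compound 2 to compound 3. The unmeasured compound 4 `COc1ccc(Cn2cc(COc3ccc4c(=O)ccoc4c3)nn2)cc1` differs from compound 2 by methoxy in place of methyl on an aromatic carbon. Within the data shown here, the steps that bear on this change are those just named, and all three are unreadable, so no direction or size of step in this assay can be drawn from them. Given that every measured compound sits at the limit, compound 4 is expected to sit there as well, with a step that the limit leaves unreadable from compound 2 to compound 4. For compound 4 the estimate is 150000 nM, within 50000 nM to 500000 nM.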

Compound 4, half-maximal inhibitory concentration: > 100000 nM
Compound 4 gave a limit, no number; the forecaster's own chance of this, stated with the estimate: 85%; the middle value lies beyond the limit too.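

No step from compound 1, compound 2 or compound 3 to compound 4 can be read in this assay, since all four compounds stand at a limit: the limit of > 100000 nM in this assay, at which 4 of the 4 values shown sit.

The compounds shown leave open how strongly any of them inhibits, and whether methoxy, methyl or fluoro makes any difference at all.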